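From benzyl to 4-fluorobenzyl on compound 3

The source may report more compounds than this note shows. Statements on the series, on what has been measured and on what is new or still open speak of the compounds shown alone.

Three compounds with a shared core, differing only in the group on sulfur, have been tested in a functional assay on PC-3 cells (Homo sapiens) for inhibition, read by MTT assay, with a stated time of 48 h; on this read-out higher numbers stand for weaker inhibition and lower numbers for stronger inhibition. Compound 1 `COc1cc(-c2nnc(SC)n2-c2ccc(N(C)C)cc2)cc(OC)c1OC` reads > 60000 nM, which is a limit of the assay and not a number. Compound 2 `CCSc1nnc(-c2cc(OC)c(OC)c(OC)c2)n1-c1ccc(N(C)C)cc1` gives 46200 nM. Compound 3 `COc1cc(-c2nnc(SCc3ccccc3)n2-c2ccc(N(C)C)cc2)cc(OC)c1OC` gives 55800 nM, which cannot be told apart from the value of compound 2. The measured steps are an at least 1.2-fold lower number from compound 1 to compound 2 (0.11 log units; that floor lies within the scatter), then an at least 1.0-fold lower number from compound 1 to compound 3 (0.03 log units; that floor lies within the scatter), and finally a 1.2-fold higher number from compound 2 to compound 3 (0.08 log units; within the scatter). None of them goes beyond the scatter.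

Compound 4 `COc1cc(-c2nnc(SCc3ccc(F)cc3)n2-c2ccc(N(C)C)cc2)cc(OC)c1OC` makes one change to compound 3, fluoro in place of hydrogen on an aromatic carbon, turning benzyl into 4-fluorobenzyl. Within the data shown here, no measured step shows this exact change. The closest evidence is the change at the same group, a 1.2-fold higher number from compound 2 to compound 3 (0.08 log units; within the scatter), so no shift beyond the scatter is expected. The expected step is a 1.1-fold lower number from compound 3 to compound 4 (0.03 log units; within the scatter). Compound 4 is estimated at 52000 nM, with an expected range from 28000 nM to 90000 nM.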

Compound 4, half-maximal inhibitory concentration: 46500 nM
Estimate against measurement, compound 4: 1.1-fold (0.05 log units) above; measured number inside the range.
By their numbers in this assay, from the lowest: compounds 2, 4 and 3 (each within the scatter of the next). At a limit, above all of these: compound 1.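

In this assay, among these compounds, the earlier compounds changed only the group on sulfur as a whole, whereas compound 4 alters the outer ring itself, and fluoro in place of hydrogen, para to a large group, gives a 1.2-fold lower number from compound 3 to compound 4 (0.08 log units; within the scatter). Set against the smaller ethyl group, the 4-fluorobenzyl group gives a 1.0-fold higher number from compound 2 to compound 4 (0.00 log units; within the scatter), so neither the ring substitution nor the larger group separates these compounds. Compound 1 is a limit and not a number, so an at least 1.2-fold lower number from compound 1 to compound 4 (0.11 log units; that floor lies within the scatter) offers only a floor, and the values here lie close to that limit: the limit of > 60000 nM in this assay, at which 1 of the 4 values shown sits.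

Going by these compounds, whether any group on this ring can move the number beyond the scatter stays open, for example a chloro, a methoxy or a carboxylic acid in place of the fluoro. Also open, on these data alone, is what an amine or a longer chain on sulfur would do.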